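Phenyl for Thiophen-2-yl at the Assay Limit

This account rests on a few compounds, and the source may have more. Where it says the series, first, only, none or still open, it means among the compounds named here.

Compound 1 `O=c1[nH]cnc2c1c(-c1cccs1)cn2[C@@H]1O[C@H](CO)[C@@H](O)[C@H]1O`: in a functional assay on HepG2 cells (Homo sapiens) for antiproliferative activity, read by XTT assay, with a stated time of 72 h (on this read-out higher numbers stand for weaker inhibition and lower numbers for stronger inhibition), compound 1 reaches only the limit > 20000 nM.
Compound 2 `Nc1nc2c(c(-c3cccs3)cn2[C@@H]2O[C@H](CO)[C@@H](O)[C@H]2O)c(=O)[nH]1`: in this assay compound 2 likewise stops at the limit > 20000 nM.
Compound 3 `CNc1ncnc2c1c(-c1ccccc1)cn2[C@@H]1O[C@H](CO)[C@@H](O)[C@H]1O`: in this assay compound 3 also gives only the limit > 20000 nM.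

Compound 1 thus stands at the limit, with no number of its own. Within the data shown here, the single step among measured compounds, a step that the two limits leave unreadable from compound 1 to compound 2, cannot be read, since both ends sit at the limit of > 20000 nM in this assay, at which 3 of the 3 values shown sit. Compound 4 `O=c1[nH]cnc2c1c(-c1ccccc1)cn2[C@@H]1O[C@H](CO)[C@@H](O)[C@H]1O` differs from compound 1 by phenyl in place of thiophen-2-yl on an aromatic carbon. Among the measured compounds shown here, no measured step bears on this change. With every shown value at the limit of > 20000 nM in this assay, at which 3 of the 3 values shown sit, nothing points to a move in this assay beyond the scatter, and compound 4 is expected to remain at the limit, a step that the limit leaves unreadable from compound 1 to compound 4. The estimate for compound 4 is 25000 nM, between 10000 nM and 60000 nM.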

Compound 4, half-maximal inhibitory concentration: > 20000 nM
Compound 4: a limit, no number; the forecaster's own chance of this, stated with the estimate: 85%; the middle value is on the limit's open side.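

No step can be read from compound 1 to compound 4, since both stop at a limit and give no number: the limit of > 20000 nM in this assay, at which 4 of the 4 values shown sit.

The compounds shown leave open whether phenyl and thiophen-2-yl differ at all in this assay, and whether any change to the shared core would give a readable value.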